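The compounds below may be only part of what the source reports. "The series", "measured", "known", "first", "only" and "open" are said of these compounds alone.

In a functional assay on HepG2 cells (Homo sapiens) for antiproliferative activity, read by CCK-8 assay, with a stated time of 48 h (a higher number here means a weaker inhibitor, a lower number a stronger inhibitor), compound 1, `COc1ccc(/C=C\c2cc(OC)c(OC)c(OC)c2)cc1OCc1ccc(CNC(C)(C)C(=O)O)cc1`, gives 6500 nM, the only exact figure available so far. Compound 2, `COc1ccc(/C=C\c2cc(OC)c(OC)c(OC)c2)cc1OCc1ccc(CN2C[C@H](O)C[C@@H]2C(=O)O)cc1`, gives > 10000 nM, which is a limit of the assay and not a number. Compound 3, `COc1ccc(/C=C\c2cc(OC)c(OC)c(OC)c2)cc1OCc1ccc(CN2CCCC[C@@H]2C(=O)O)cc1`, has not yet been measured. It keeps the core of compound 1 and changes one group: 2-carboxypiperidin-1-yl in place of (1-carboxy-1-methylethyl)amino on a saturated chain carbon bound to an aromatic carbon. Here 2-carboxypiperidin-1-yl stands in place of (1-carboxy-1-methylethyl)amino, on a saturated chain carbon bound to an aromatic carbon. Within the data shown here, one measured step bears on this, a swap at the same place: an at least 1.5-fold higher number from compound 1 to compound 2 (0.18 log units; that floor lies within the scatter). That floor lies within the scatter, so it supports only a cautious expectation of a slightly higher number in this assay, possibly nothing beyond the scatter. The expected change is a 1.4-fold higher number from compound 1 to compound 3 (0.14 log units; within the scatter). Compound 3 is estimated at 9000 nM, with an expected range from 3500 nM to 20000 nM.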

Compound 3, half-maximal inhibitory concentration: > 10000 nM
Compound 3 was reported as a limit; the forecaster's own chance of this, stated with the estimate: 40%; middle value at least 1.1-fold (0.04 log units) away from the limit.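

In this assay, compound 3 gives > 10000 nM, which is a limit of the assay and not a number. With 2-carboxypiperidin-1-yl in place of (1-carboxy-1-methylethyl)amino on a saturated chain carbon bound to an aromatic carbon, the result is an at least 1.5-fold higher number from compound 1 to compound 3 (0.18 log units; that floor lies within the scatter), so no real loss can be claimed, although a second ring-bearing group at this place, this one without a hydroxy group, gives no exact figure either. The step between compound 2 and compound 3 cannot be read, and both ring-bearing groups end at the same ceiling: the limit of > 10000 nM in this assay, at which 2 of the 3 values shown sit.

From the compounds shown here alone, whether the carboxylic acid matters at all stays open, and a simple amine such as dimethylamino or a methyl ester at this place would test it. A longer chain between the nitrogen and the carboxylic acid is also untested among the compounds shown.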